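From methyl ester to aldehyde on the shared core

This account rests on a few compounds, and the source may have more. Where it says the series, first, only, none or still open, it means among the compounds named here.

Measured in a functional assay on SK-OV-3 cells (Homo sapiens) for inhibition, read by CCK-8 assay, with a stated time of 70 h; on this read-out lower numbers stand for stronger inhibition and higher numbers for weaker inhibition:
- compound 1 `O=C(O)c1cccc(COc2ccc(OCCOCCNC3CCCC3)cc2)c1`: > 100000 nM (a limit of the assay)
- compound 2 `COc1ccc(COc2ccc(OCCOCCNC3CCCC3)cc2)cc1`: 15700 nM
- compound 3 `COC(=O)c1ccc(COc2ccc(OCCOCCNC3CCCC3)cc2)cc1`: 6990 nM

In this assay compound 3 gives 6990 nM, the lower of the two true numbers. Its nearest neighbour is compound 2, and the gap is a 2.2-fold lower number from compound 2 to compound 3 (0.35 log units; beyond the scatter). Compound 1 offers only a limit, noted as the limit of > 100000 nM in this assay, at which 1 of the 3 values shown sits.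

Compound 4 `O=Cc1ccc(COc2ccc(OCCOCCNC3CCCC3)cc2)cc1` differs from compound 3 by hydrogen in place of methoxy on a carbonyl carbon. This is hydrogen in place of methoxy on a carbonyl carbon, so methoxycarbonyl becomes formyl.

Going by the values given here, no measured step makes this exact change. The closest guide is a 2.2-fold lower number from compound 2 to compound 3 (0.35 log units; beyond the scatter), a modest step at the same end of the molecule. Two further steps are an at least 6.3-fold lower number from compound 1 to compound 2 (0.80 log units; beyond the scatter) and an at least 14-fold lower number from compound 1 to compound 3 (1.15 log units; beyond the scatter), but both start from a limit and replace 3-carboxyphenyl, so they say little about the size of this change.

A modest step toward a higher number is therefore expected, though one within the scatter would not surprise. The expected change is a 1.3-fold higher number from compound 3 to compound 4 (0.11 log units; within the scatter). For compound 4 the estimated value is 9000 nM, with an expected range from 3500 nM to 22000 nM.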

Compound 4, half-maximal inhibitory concentration: 45000 nM
For compound 4 the middle estimate is 5.0-fold (0.70 log units) below the measured one; measured number above the stated range.
By their numbers in this assay, from the lowest: compound 3; then compound 2; then compound 4. At a limit, above all of these: compound 1.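

In this assay, going by these compounds alone, the group on this carbonyl carbon matters more than the earlier compounds suggested: replacing methoxy with hydrogen, so that methoxycarbonyl becomes formyl, gives a step (a 6.4-fold higher number from compound 3 to compound 4 (0.81 log units; beyond the scatter)). Within the data shown here, this step is larger than the one seen between compound 2 and compound 3. The formyl group also falls behind the methoxy group on the same aromatic carbon (a 2.9-fold higher number from compound 2 to compound 4 (0.46 log units; beyond the scatter)), so compound 4 has the highest true number of the three compounds that give one, and the order runs compound 3, compound 2, compound 4. The remaining step (an at least 2.2-fold lower number from compound 1 to compound 4 (0.34 log units; beyond the scatter)) is only a bound, since compound 1 stands at a limit of the assay: the limit of > 100000 nM in this assay, at which 1 of the 4 values shown sits.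

The compounds shown do not separate the loss of the methoxy group from any other part of the change at the carbonyl carbon. They do not explain why the number moves this far. A primary amide or a hydroxymethyl group in place of formyl could narrow this down, and a 4-carboxyphenyl group would show how much of the limit seen for compound 1 goes with the acid itself rather than with its place on the ring.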